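Swapping phenyl for pyridin-2-yl on a cytotoxicity core

The source may report more compounds than this note shows. Statements on the series, on what has been measured and on what is new or still open speak of the compounds shown alone.

Measured compounds:
- compound 1 `O=C1NC(c2ccccc2)CN1c1cnn2c1CN(C(=O)Nc1cc(F)c(F)c(F)c1)C(C1CC1)C2`: 38500 nM
- compound 2 `O=C1CC(Oc2ncc(F)cn2)CN1c1cnn2c1CN(C(=O)Nc1cc(F)c(F)c(F)c1)C(C1CC1)C2`: 96200 nM
- compound 3 `O=C1CC(c2ccccc2)CN1c1cnn2c1CN(C(=O)Nc1cc(F)c(F)c(F)c1)C(C1CC1)C2`: 12800 nM

These three compounds were tested in a toxicity assay on HepG2 2.2.15 cells (Homo sapiens) for cytotoxicity, read by CellTiter-Glo; a lower number here means that less compound is tolerated, a higher number that more compound is tolerated. Compound 3 gives the lowest number of the three; compound 1 is its nearest neighbour and compound 2 the furthest, and both gaps are beyond the scatter. The step of a 3.0-fold lower number from compound 1 to compound 3 (0.48 log units; beyond the scatter) shows the pyrrolidinone core giving a lower number than the imidazolidinone core, and a 7.5-fold lower number from compound 2 to compound 3 (0.88 log units; beyond the scatter) shows the phenyl group giving a lower number than the (5-fluoropyrimidin-2-yl)oxy group on the same saturated ring carbon.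

Compound 4 `O=C1CC(c2ccccn2)CN1c1cnn2c1CN(C(=O)Nc1cc(F)c(F)c(F)c1)C(C1CC1)C2` differs from compound 3 by one change: pyridin-2-yl in place of phenyl on a saturated ring carbon. This is a small change at the position where the step from compound 2 to compound 3 acted, so that step is the most relevant comparison, though the group entering here is not the same. Since a six-membered ring with one nitrogen replaces a ring of carbon only, the number for compound 4 is expected to move modestly back upward from compound 3, a step of a 1.6-fold higher number from compound 3 to compound 4 (0.19 log units; within the scatter) rather than anything as large as a 7.5-fold lower number from compound 2 to compound 3 (0.88 log units; beyond the scatter). Compound 4 is therefore estimated at 20000 nM, with a plausible range from 8000 nM to 50000 nM.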

Compound 4, half-maximal cytotoxic concentration: 96200 nM
For compound 4 the middle estimate is 4.8-fold (0.68 log units) below the measured one; measured number above the stated range.
By their numbers in this assay, from the lowest: compound 3; then compound 1; then compounds 2 and 4 (each within the scatter of the next).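

At this saturated ring carbon in this assay, putting a ring nitrogen in place of a ring carbon gives a 7.5-fold higher number from compound 3 to compound 4 (0.88 log units; beyond the scatter), so the low number of compound 3 is tied to phenyl itself and not to any six-membered aromatic ring at this place. The earlier step from the (5-fluoropyrimidin-2-yl)oxy group to phenyl suggested that a large change of group was needed to move the number this far, yet no change at the digits printed from compound 2 to compound 4 (within the scatter) shows that pyridin-2-yl and that group cannot be told apart here, although the two differ in more than one feature. The remaining step, a 2.5-fold higher number from compound 1 to compound 4 (0.40 log units; beyond the scatter), places 2-oxo-4-(pyridin-2-yl)pyrrolidin-1-yl on the opposite side of 2-oxo-4-phenylimidazolidin-1-yl from 2-oxo-4-phenylpyrrolidin-1-yl, so which of these side groups gives the higher number depends on the group at this carbon.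

No measurement here accounts for the size of this step. Going by these compounds, it remains open whether pyridin-3-yl or pyridin-4-yl would behave like pyridin-2-yl, whether an amine or a carboxylic acid on the phenyl ring would move the number in the same way, and whether the same swap would act alike on the core of compound 1.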